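Shortening the Hydroxycarbamoyl Chain of Compound 2

The compounds below may be only part of what the source reports. "The series", "measured", "known", "first", "only" and "open" are said of these compounds alone.

In a functional assay on HCT-116 cells (Homo sapiens) for inhibition, read by MTT assay, with a stated time of 72 h (a lower number here means a stronger inhibitor, a higher number a weaker inhibitor), compound 1 `Nc1ncnc2c1c(-c1cnc3[nH]ccc3c1)nn2CCCCCC(=O)NO` gives 63700 nM, while compound 2 `Nc1ncnc2c1c(-c1cnc3[nH]ccc3c1)nn2CCCCCCCCCC(=O)NO` gives 18700 nM, the lower of the two numbers. Compound 3 `Nc1ncnc2c1c(-c1cnc3[nH]ccc3c1)nn2CCCCCCC(=O)NO` differs from compound 2 by hydroxycarbamoyl in place of 3-(hydroxycarbamoyl)propyl on a saturated chain carbon, six bonds along the chain from an aromatic nitrogen, on a saturated chain carbon, six bonds along the chain from an aromatic nitrogen. Among the measured compounds shown here, the only measured step bearing on this change, a 3.4-fold lower number from compound 1 to compound 2 (0.53 log units; beyond the scatter), placed 4-(hydroxycarbamoyl)butyl where hydroxycarbamoyl stood, and compound 3 reverses part of that extension. A smaller move towards a higher number is therefore expected in this assay. The estimated change is a 2.1-fold higher number from compound 2 to compound 3 (0.33 log units; beyond the scatter). Compound 3 is expected at 40000 nM, with an estimated range of 15000 nM to 85000 nM.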

Compound 3, half-maximal inhibitory concentration: 9860 nM
Beside the measured number, compound 3's estimate is 4.1-fold (0.61 log units) above it; measured number below the stated range.
By their numbers in this assay, from the lowest: compounds 3 and 2 (each within the scatter of the next); then compound 1.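

In this assay, shortening the chain does not return the reading towards that of compound 1: a 1.9-fold lower number from compound 2 to compound 3 (0.28 log units; within the scatter), so these two chain lengths cannot be told apart. Nearly all of the difference already appears with (hydroxycarbamoyl)methyl in place of hydroxycarbamoyl, which gives a 6.5-fold lower number from compound 1 to compound 3 (0.81 log units; beyond the scatter), and the longer chain of compound 2 adds nothing beyond the scatter. No measurement offered here explains this flattening. On these data alone, it remains open whether a chain longer than that of compound 2 would hold this level or shift it, and whether a carboxylic acid in place of hydroxycarbamoyl would retain it.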